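A few compounds are considered here, and "the series" means these few. Any claim that something is new, unique, unknown or untested is made for them only; others in the source may bear on it.

Measured in a functional assay on A549 cells (Homo sapiens) for cytotoxicity, read by MTT assay, with a stated time of 72 h; a higher number here means a weaker inhibitor, a lower number a stronger inhibitor:
- Compound 1 `Cc1ccc(F)cc1NC(=O)CN1CCN(c2nnc(Cc3ccncc3)c3ccccc23)CC1`: 38900 nM
- Compound 2 `O=C(CN1CCN(c2nnc(Cc3ccncc3)c3ccccc23)CC1)Nc1cc(C(F)(F)F)ccc1Cl`: 1850 nM
- Compound 3 `O=C(CN1CCN(c2nnc(Cc3ccncc3)c3ccccc23)CC1)Nc1ccc(F)c(F)c1`: 3790 nM

Among these three, compound 3 sits in the middle, with a 2.0-fold higher number from compound 2 to compound 3 (0.31 log units; beyond the scatter) and a 10-fold lower number from compound 1 to compound 3 (1.01 log units; beyond the scatter). Compound 4 `Cc1cccc(Cl)c1NC(=O)CN1CCN(c2nnc(Cc3ccncc3)c3ccccc23)CC1` carries 2-chloro-6-methylphenyl in place of 3,4-difluorophenyl on an amide-type nitrogen.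

Within the data shown here, three measured steps bear on this change, all at the same place. The group of compound 1, 5-fluoro-2-methylphenyl, also has a methyl, and the large steps away from it are a 21-fold lower number from compound 1 to compound 2 (1.32 log units; beyond the scatter) and a 10-fold lower number from compound 1 to compound 3 (1.01 log units; beyond the scatter). The group of compound 2, 2-chloro-5-(trifluoromethyl)phenyl, also has a chloro, and it lies close to compound 3. Among the measured compounds shown here, the entering group thus shares one feature with each, and no measured compound has both. A moderate move towards a weaker inhibitor in this assay is therefore expected, landing between compound 3 and compound 1. The expected change is a 2.1-fold higher number from compound 3 to compound 4 (0.32 log units; beyond the scatter). Compound 4 is estimated at 8000 nM, with an expected range of 2000 nM to 30000 nM.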

Compound 4, half-maximal inhibitory concentration: 7190 nM
Estimate against measurement, compound 4: 1.1-fold (0.05 log units) above; the range from low to high includes it.
By their numbers in this assay, from the lowest: compound 2; then compounds 3 and 4 (each within the scatter of the next); then compound 1.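

In this assay, 2-chloro-6-methylphenyl and 3,4-difluorophenyl on the amide-type nitrogen are not separated, with a 1.9-fold higher number from compound 3 to compound 4 (0.28 log units; within the scatter) as the step, so groups with quite different substituents can give readings within the scatter of each other. The methyl shared with 5-fluoro-2-methylphenyl does not carry the high number of that group, given a 5.4-fold lower number from compound 1 to compound 4 (0.73 log units; beyond the scatter) as the step, and the chloro shared with 2-chloro-5-(trifluoromethyl)phenyl does not carry its low number, given a 3.9-fold higher number from compound 2 to compound 4 (0.59 log units; beyond the scatter) as the step. No measurement at hand accounts for these differences.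

The compounds shown leave open how a phenyl bearing only a chloro or only a methyl would read in this assay as a test of each feature alone. Also open, from the compounds shown here alone, is what an amine or a carboxylic acid on the phenyl would do.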